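The source may report more compounds than this note shows. Statements on the series, on what has been measured and on what is new or still open speak of the compounds shown alone.

Measured so far:
Compound 1 `Cn1c(=O)c(C(=O)O)c(O)c2cc(Cc3ccc(F)cc3)ccc21` gives > 10000 nM
Compound 2 `CCOC(=O)c1c(O)c2cc(OC)ccc2n(C)c1=O` gives > 10000 nM
Compound 3 `CCOC(=O)c1c(O)c2cc(Cc3ccccc3)ccc2n(C)c1=O` gives > 10000 nM

In a functional assay on HCT-116 cells (Homo sapiens) for cytotoxicity, read by MTT assay, with a stated time of 72 h (on this read-out higher numbers stand for lower toxicity in this test and lower numbers for higher toxicity in this test), compound 3 gives > 10000 nM as a limit and not a number. The whole picture so far is the limit of > 10000 nM in this assay, at which 3 of the 3 values shown sit, and no more. Compound 4 `CCOC(=O)c1c(O)c2cc(Cc3ccc(F)cc3)ccc2n(C)c1=O` differs from compound 3 by fluoro in place of hydrogen on an aromatic carbon, so benzyl becomes 4-fluorobenzyl (fluoro in place of hydrogen on an aromatic carbon). For the measured compounds named here, the one measured step that bears on this is a step that the two limits leave unreadable from compound 2 to compound 3 and it offers no size to carry over. Compound 1 also carries 4-fluorobenzyl and gives > 10000 nM as a limit too. No step beyond the scatter is therefore expected, and another limit is the likeliest report. The expected step is a step that the limit leaves unreadable from compound 3 to compound 4 on this estimate. Compound 4 is expected at 15000 nM (estimated range 5000 nM to 30000 nM).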

Compound 4, half-maximal cytotoxic concentration: > 10000 nM
Compound 4 gave a limit, no number (the forecaster's own chance of this, stated with the estimate: 80%); the middle value is on the limit's open side.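

Compound 1, compound 2, compound 3 and compound 4 each give only a limit, so no step between them can be read in this assay: the limit of > 10000 nM in this assay, at which 4 of the 4 values shown sit.

Which change, if any, would give a measurable number in this test stays open.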